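Methoxy to ethoxy on the carbonyl of compound 3

A few compounds are considered here, and "the series" means these few. Any claim that something is new, unique, unknown or untested is made for them only; others in the source may bear on it.

Among the measured compounds shown here, in a functional assay on PC-3 cells (Homo sapiens) for antiproliferative activity, with a stated time of 48 h (a higher number here means a weaker inhibitor, a lower number a stronger inhibitor), compound 3 `CCN(CC)c1ccc(-c2ccc(C(=O)OC)cc2)nn1` gives 90 nM, the only actual number. Compound 1 `CCN(CC)c1ccc(-c2cccc(C#N)c2)nn1` reaches only the assay limit, > 25000 nM. Compound 2 `CCN(CC)c1ccc(-c2ccc(C(C)=O)cc2)nn1` also reaches only that limit, > 25000 nM. Compound 4 `CCOC(=O)c1ccc(-c2ccc(N(CC)CC)nn2)cc1` carries methyl in place of hydrogen on a saturated chain carbon bound to an oxygen next to a carbonyl group, so methoxycarbonyl becomes ethoxycarbonyl (methyl in place of hydrogen on a saturated chain carbon bound to an oxygen next to a carbonyl group). For the measured compounds named here, one measured step bears on this: an at least 270-fold lower number from compound 2 to compound 3 (2.44 log units; beyond the scatter), a large step that also changes the group on the carbonyl carbon. A much smaller change is expected here, with the number rising modestly: a 2.4-fold higher number from compound 3 to compound 4 (0.39 log units; beyond the scatter) is the estimated step. For compound 4 the estimated value is 220 nM, within a range of 45 nM to 2500 nM.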

Compound 4, half-maximal inhibitory concentration: 1000 nM
The estimate for compound 4 lay 4.5-fold (0.66 log units) below the measured number, within the range that was stated.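

In this assay, the change from methoxy to ethoxy on the carbonyl is not silent: the step is an 11-fold higher number from compound 3 to compound 4 (1.05 log units; beyond the scatter), so a single added methyl on this saturated chain carbon bound to an oxygen next to a carbonyl group already costs activity. Even with that added methyl, the result is still an at least 25-fold lower number from compound 2 to compound 4 (1.39 log units; beyond the scatter), so ethoxycarbonyl keeps part of the gain seen with methoxycarbonyl. That step is open-ended, as compound 2 stands at a limit of the assay: the limit of > 25000 nM in this assay, at which 2 of the 4 values shown sit.

Open, as far as these compounds go, is how a longer chain or a branched isopropyl group on this oxygen would read. Also open, from the compounds shown here alone, is how a carboxylic acid or an amide would compare on the same carbonyl carbon.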